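A few compounds are considered here, and "the series" means these few. Any claim that something is new, unique, unknown or untested is made for them only; others in the source may bear on it.

Measured so far in a functional assay on MGC-803 cells (Homo sapiens) for antiproliferative activity, read by MTT assay, with a stated time of 72 h; on this read-out higher numbers stand for weaker inhibition and lower numbers for stronger inhibition:
- compound 1 `CCCSc1nc(N/N=C(\C)c2ccccc2O)c2nnn(Cc3ccccc3Cl)c2n1` gives 35000 nM
- compound 2 `CCCSc1nc(N/N=C/c2ccc([N+](=O)[O-])cc2)c2nnn(Cc3ccccc3)c2n1` gives 10100 nM
- compound 3 `C#CCSc1nc(N/N=C/c2c(O)ccc3ccccc23)c2nnn(Cc3ccccc3)c2n1` gives 10500 nM

Among these three, compound 2 has the lowest number in this assay. Its value and that of compound 3 lie within the usual scatter of each other, so the two cannot be told apart. Compound 1 stands apart with a clearly higher number, beyond the scatter, meaning weaker inhibition.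

Compound 4 `CCCSc1nc(N/N=C/c2ccc(Br)cc2)c2nnn(Cc3ccccc3)c2n1` has not been measured. It differs from compound 2 in one place: bromo in place of nitro on an aromatic carbon. Among the compounds with values here, no pair of measured compounds shows the effect of such a swap, so there is nothing here to anchor its direction. The step of a 1.3-fold higher number from compound 2 to compound 4 (0.11 log units; within the scatter) is expected to be small, most likely not beyond the scatter, with a slight lean toward a higher number. On that basis compound 4 is estimated to give 13000 nM in this assay, within a range from 4500 nM to 40000 nM.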

Compound 4, half-maximal inhibitory concentration: 34900 nM
Compound 4: middle estimate off by 2.7-fold (0.43 log units), on the low side; the measured number falls inside the stated range.
By their numbers in this assay, from the lowest: compounds 2 and 3 (each within the scatter of the next); then compounds 4 and 1 (each within the scatter of the next).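

In this assay, within the data shown here, the change from 4-nitrophenyl to 4-bromophenyl gives a 3.5-fold higher number from compound 2 to compound 4 (0.54 log units; beyond the scatter) and provides the only direct comparison between compounds that differ in one place. It shows that the group at this position, para to a large group on the six-membered aromatic ring, matters for this read-out: with the rest of the structure unchanged, bromo goes with weaker inhibition than nitro. Nothing given here explains the difference.

The compounds shown leave open how an amine, a methoxy group or a carboxylic acid would compare with nitro and bromo at this same position. They also leave open whether the swap from nitro to bromo would give a step of similar size alongside the other side chains seen in compound 1 and compound 3.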